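The compounds below may be only part of what the source reports. "The series", "measured", "known", "first", "only" and "open" are said of these compounds alone.

In a functional assay on HeLa cells (Homo sapiens) for antiproliferative activity, read by MTT assay, with a stated time of 48 h (a higher number here means a weaker inhibitor, a lower number a stronger inhibitor), compound 3 `S=c1oc(-c2ccc3c(c2)OCCO3)nn1CN1CCN(c2ccccc2Cl)CC1` gives 37400 nM, and it stands alongside compound 1 `Fc1ccccc1N1CCN(Cn2nc(-c3ccc4c(c3)OCCO4)oc2=S)CC1`, which gives 37300 nM; the two numbers shown differ by a 1.0-fold higher number from compound 1 to compound 3 (0.00 log units; within the scatter). Compound 2 `S=c1oc(-c2ccc3c(c2)OCCO3)nn1CN1CCN(c2cccc(Cl)c2Cl)CC1` reaches only a limit, > 50000 nM, as recorded in the limit of > 50000 nM in this assay, at which 1 of the 3 values shown sits. The steps that change the aryl group, an at least 1.3-fold higher number from compound 1 to compound 2 (0.12 log units; that floor lies within the scatter) and an at least 1.3-fold lower number from compound 2 to compound 3 (0.12 log units; that floor lies within the scatter), likewise stay at floors inside the scatter. Compound 4 `O=[N+]([O-])c1ccc(N2CCN(Cn3nc(-c4ccc5c(c4)OCCO5)oc3=S)CC2)cc1` differs from compound 3 by 4-nitrophenyl in place of 2-chlorophenyl on an amine nitrogen in a ring. For the measured compounds named here, no measured step replaces the whole aryl group in this manner, so the three closely grouped values are the only guide. Compound 4 is therefore expected to show a 1.1-fold higher number from compound 3 to compound 4 (0.03 log units; within the scatter), no shift beyond the scatter. The estimate for compound 4 is 40000 nM, between 15000 nM and 100000 nM.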

Compound 4, half-maximal inhibitory concentration: 31700 nM
Compound 4: the middle estimate sits 1.3-fold (0.10 log units) above what was measured; measured number inside the range.
By their numbers in this assay, from the lowest: compounds 4, 1 and 3 (each within the scatter of the next). At a limit, above all of these: compound 2.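

In this assay, 4-nitrophenyl on this amine nitrogen in a ring, which brings in 2 hydrogen-bond acceptors, gives no shift that can be told from the scatter: a 1.2-fold lower number from compound 3 to compound 4 (0.07 log units; within the scatter), and a 1.2-fold lower number from compound 1 to compound 4 (0.07 log units; within the scatter). Compounds 1, 3 and 4 thus show that the level seen with the halogen-bearing phenyl groups of compounds 1 and 3 also holds for a phenyl group with no halogen. The remaining step, an at least 1.5-fold lower number from compound 2 to compound 4 (0.19 log units; that floor lies within the scatter), gives only a floor, and compound 2 stays at a limit: the limit of > 50000 nM in this assay, at which 1 of the 4 values shown sits.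

As far as these compounds go, whether an amine or a carboxylic acid on the phenyl ring would shift the number beyond the scatter stays open. So does the effect of replacing the aryl group with a longer alkyl chain.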